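This account rests on a few compounds, and the source may have more. Where it says the series, first, only, none or still open, it means among the compounds named here.

Measured so far, in an ADME assay on microsomes from liver (Rattus norvegicus) for metabolic stability, read by LC-MS, with a stated time of 15 min, tested at 1 uM; on this read-out higher numbers stand for a more stable compound and lower numbers for a less stable compound:

- compound 1 `O=C(CCS(=O)(=O)c1cccc2ncsc12)N1CCN(c2ccc(C(F)(F)F)cn2)CC1`: 41%
- compound 2 `Cc1cc(F)cnc1N1CCN(C(=O)CCCc2cccc3ncccc23)[C@@H](C)C1`: 0.2%
- compound 3 `O=C(CCS(=O)(=O)c1cccc2ncsc12)N1CCN(c2ccnc(C(F)(F)F)c2)CC1`: "not determined" (no result reported)

The two numbers in hand lie far apart: compound 1 gives 41%, while compound 2 gives 0.2%. Compound 3 has no place on this scale, as its entry reads "not determined" (no result reported) and no result was reported. The next compound is compound 4 `O=C(CCS(=O)(=O)c1cccc2ncsc12)N1CCN(c2ccncc2F)CC1`. The structural change from compound 3 is 3-fluoropyridin-4-yl in place of 2-(trifluoromethyl)pyridin-4-yl on an amine nitrogen in a ring. In words, 3-fluoropyridin-4-yl stands in place of 2-(trifluoromethyl)pyridin-4-yl on an amine nitrogen in a ring, and the rest of the structure stays as it is.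

Among the measured compounds shown here, no measured step covers this exchange, and with no number for compound 3 there is no starting value to move from. The working expectation is therefore a step no larger than the scatter in this assay, with no direction assigned. The nearest anchor is compound 1 at 41%, which shares the core of compound 4 more closely than compound 2 does. The range stays wide, as it rests on a single anchor. For compound 4 the estimated value in this assay is 45%, with an expected range from 20% to 75%.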

Compound 4, percent of the compound remaining: 29%
For compound 4 the middle estimate is 16 percentage points above the measured one, within the range that was stated.
By their numbers in this assay, from the lowest: compound 2; then compound 4; then compound 1.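

Notes on the aryl group on the ring amine nitrogen: in this assay the exchange of 2-(trifluoromethyl)pyridin-4-yl for 3-fluoropyridin-4-yl cannot be read, as compound 3 has no number to start from, so this position can be judged only through compound 1. Against 5-(trifluoromethyl)pyridin-2-yl on the same nitrogen, 3-fluoropyridin-4-yl gives a number 12 percentage points lower from compound 1 to compound 4 (beyond the scatter) and is the first measured change at this position on the shared core. No supporting data on the compounds explain the size or direction of this step.

Among the compounds shown here, the pair does not separate the loss of trifluoromethyl and the arrival of fluorine from the change from a pyridin-2-yl to a pyridin-4-yl group, as both differences lie within the one exchange. Also open, from the compounds shown here alone, is where an unsubstituted pyridin-4-yl, or a pyridin-4-yl bearing a nitrile or a methoxy group, would stand in this assay on the same nitrogen relative to compound 1 and compound 4.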